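This account rests on a few compounds, and the source may have more. Where it says the series, first, only, none or still open, it means among the compounds named here.

Measured compounds in an assay on isolated protein for displacement of a labelled ligand from 5-hydroxytryptamine receptor 6 (Homo sapiens), read by scintillation counting, with a stated time of 1 h; on this read-out lower numbers stand for stronger inhibition and higher numbers for weaker inhibition:
- compound 1, `CC(=O)N1CCN(c2cccc3c2ccn3S(=O)(=O)c2ccccc2)CC1`, gives 714 nM
- compound 2, `CN(C)c1cccc2c1ccn2S(=O)(=O)c1ccccc1`, gives 65 nM
- compound 3, `O=S(=O)(c1ccccc1)n1ccc2c(-c3ccncc3)cccc21`, gives 1510 nM

Compound 2 holds the lowest number of the three. The steps to it are large: an 11-fold lower number from compound 1 to compound 2 (1.04 log units; beyond the scatter) and, going the other way, a 23-fold higher number from compound 2 to compound 3 (1.37 log units; beyond the scatter); the step of a 2.1-fold higher number from compound 1 to compound 3 (0.33 log units; beyond the scatter) is the only modest one. All three measured steps change the group on the aromatic carbon of the shared core and leave the sulfonyl side untouched.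

Compound 4, `CN(C)c1cccc2c1ccn2S(=O)(=O)C1CCCCC1`, differs from compound 2 at that untouched side: cyclohexyl in place of phenyl on a sulfonyl sulfur. For the measured compounds named here, no measured step bears on this change, so nothing in this assay indicates its direction or size. The expectation is therefore anchored on compound 2 alone and carries a wide range; the step of a 3.1-fold higher number from compound 2 to compound 4 (0.49 log units; beyond the scatter) is an estimate, not a reading. For compound 4 the estimated value in this assay is 200 nM, with a range from 50 nM to 2000 nM.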

Compound 4, inhibition constant: 4890 nM
Compound 4: the middle estimate sits 24-fold (1.39 log units) below what was measured, and the stated range ends below it.
By their numbers in this assay, from the lowest: compound 2; then compound 1; then compound 3; then compound 4.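

In this assay the sulfonyl side proves to be no bystander: with the dimethylamino group held constant, the swap gives a 75-fold higher number from compound 2 to compound 4 (1.88 log units; beyond the scatter) and is larger than any step seen at the aromatic carbon. Phenyl and cyclohexyl match in every count printed, with the same carbon count, no hydrogen-bond donors or acceptors and no net charge. Phenyl is an aromatic ring and cyclohexyl is a non-aromatic one. Nothing available explains why this swap has so large an effect.

From the compounds shown here alone, whether the same step holds with 4-acetylpiperazin-1-yl or pyridin-4-yl on the aromatic carbon remains open. So does how a smaller methyl, a 4-chlorophenyl or a naphthyl group on the sulfonyl sulfur would compare with phenyl.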